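Phenyl to 4-hydroxyphenyl on the shared core

This account rests on a few compounds, and the source may have more. Where it says the series, first, only, none or still open, it means among the compounds named here.

- compound 1 `C[C@H]1CC[C@@H]2[C@@H](OC(=O)[C@]23CC(c2c(Cl)cccc2Cl)=NO3)[C@]2(C)C(=O)C=C[C@@]12O`: 43000 nM
- compound 2 `C[C@H]1CC[C@@H]2[C@@H](OC(=O)[C@]23CC(c2ccccc2Br)=NO3)[C@]2(C)C(=O)C=C[C@@]12O`: 44000 nM
- compound 3 `C[C@H]1CC[C@@H]2[C@@H](OC(=O)[C@]23CC(c2ccccc2)=NO3)[C@]2(C)C(=O)C=C[C@@]12O`: 45400 nM

In a functional assay on SW-620 cells (Homo sapiens) for cytotoxicity, read by sulforhodamine B assay, with a stated time of 48 h (a lower number here means a stronger inhibitor, a higher number a weaker inhibitor), compound 3 stands level with compound 1 and compound 2, within the scatter of both. Compound 4 `C[C@H]1CC[C@@H]2[C@@H](OC(=O)[C@]23CC(c2ccc(O)cc2)=NO3)[C@]2(C)C(=O)C=C[C@@]12O` carries one change from compound 3: hydroxy in place of hydrogen on an aromatic carbon. Among the measured compounds shown here, three measured steps bear on this aromatic ring: a 1.0-fold higher number from compound 1 to compound 2 (0.01 log units; within the scatter), a 1.1-fold higher number from compound 1 to compound 3 (0.02 log units; within the scatter) and a 1.0-fold higher number from compound 2 to compound 3 (0.01 log units; within the scatter). For the measured compounds named here, all stay within the scatter, although none of the measured compounds carries a hydroxy. On that limited evidence, no change beyond the scatter is expected, and the expected result is a 1.1-fold lower number from compound 3 to compound 4 (0.03 log units; within the scatter). In this assay compound 4 is estimated at 42000 nM, with an expected range of 20000 nM to 80000 nM.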

Compound 4, half-maximal inhibitory concentration: 89000 nM
Beside the measured number, compound 4's estimate is 2.1-fold (0.33 log units) below it; the measured number lies above the stated range.
By their numbers in this assay, from the lowest: compounds 1, 2, 3 and 4 (each within the scatter of the next, the first and the last beyond it).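

In this assay, among the compounds shown here, compound 4 is the first member of the series with a hydroxy on the aromatic ring, para to a large group. Its step from the unsubstituted phenyl stays within the scatter (a 2.0-fold higher number from compound 3 to compound 4 (0.29 log units; within the scatter)), while the steps from the halogenated rings pass modestly beyond it (a 2.0-fold higher number from compound 2 to compound 4 (0.31 log units; beyond the scatter); a 2.1-fold higher number from compound 1 to compound 4 (0.32 log units; beyond the scatter)), the first separations seen among these compounds. Nothing measured here bears on a cause for these steps.

The compounds shown leave open whether a methoxy, an amine or a carboxylic acid at this same place would read like hydroxy. Going by these compounds, whether hydroxy elsewhere on this ring would do the same also remains open.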